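The source may hold more compounds than are shown below. What is called first, only, known or untested is meant among the compounds shown, and "the series" means these compounds.

Compound 2 `Cc1ccc(NC(=O)CCC(=O)OCCCCCCSc2ccc([N+](=O)[O-])c3nonc23)cc1` is a nitrobenzofurazan thioether carrying an ester-linked chain that ends in an amide. In an ADME assay on L02 cells (Homo sapiens) for cytotoxicity, read by MTT assay, with a stated time of 72 h (a lower number here means a stronger inhibitor, a higher number a weaker inhibitor), compound 2 gives 7320 nM, and the related compound 1 `O=C(CCC(=O)OCCCCCCSc1ccc([N+](=O)[O-])c2nonc12)Nc1ccccc1Cl` gives 5850 nM; the step of a 1.3-fold higher number from compound 1 to compound 2 (0.10 log units; within the scatter) lies within the scatter, so the two are not separable. Compound 3 `O=C(CCC(=O)N1CCOCC1)OCCCCCCSc1ccc([N+](=O)[O-])c2nonc12` differs from compound 2 by morpholin-4-yl in place of (4-methylphenyl)amino on a carbonyl carbon. Among the measured compounds shown here, no measured step replaces the whole amide substituent, so that single step offers little guidance. I expect a 1.3-fold higher number from compound 2 to compound 3 (0.11 log units; within the scatter) for compound 3, at most a modest weakening. My estimate for compound 3 is 9500 nM, within 4000 nM to 25000 nM.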

Compound 3, half-maximal inhibitory concentration: 3240 nM
Compound 3: middle estimate off by 2.9-fold (0.47 log units), on the high side; the whole stated range lies above it.
By their numbers in this assay, from the lowest: compounds 3, 1 and 2 (each within the scatter of the next, the first and the last beyond it).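

Within this assay the morpholin-4-yl group gives a step beyond the scatter when it replaces (4-methylphenyl)amino on this carbonyl carbon (a 2.3-fold lower number from compound 2 to compound 3 (0.35 log units; beyond the scatter)). Against (2-chlorophenyl)amino the same kind of change stays within the scatter (a 1.8-fold lower number from compound 1 to compound 3 (0.26 log units; within the scatter)). So this place can shift the number modestly, and a non-aromatic ring without the amide hydrogen does not weaken the result; nothing measured here explains the shift. Going by these compounds, whether the ring oxygen matters remains open, and piperidin-1-yl on this carbonyl carbon would test that. On these data alone, a carboxylic acid at the same place is also open.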